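This account rests on a few compounds, and the source may have more. Where it says the series, first, only, none or still open, it means among the compounds named here.

Working notes on the series, read in a functional assay on the whole organism (strain Kunming) with Mus musculus as the target, with a stated time of 0.5 h; a higher number here means that more compound is needed for the effect, a lower number that less compound is needed. Compound 1 (`COc1cc(OC)c(OC)cc1/C=C/COC(=O)/C=C/c1ccc(OC)c(OC)c1`) gives > 723 umol/kg, which is a limit and not a number. Compound 2 (`COc1cc(OC)c(OC)cc1/C=C/COC(=O)/C=C/c1ccc(OC)c(OC)c1OC`) gives > 674 umol/kg, which is also a limit. Within the data shown here, compound 1 therefore has no measured number to stand on, and the only other value available offers no number either.

Compound 3 (`COc1cc(OC)c(OC)cc1/C=C/COC(=O)/C=C/c1ccccc1Cl`) carries 2-chlorophenyl in place of 3,4-dimethoxyphenyl on a double-bonded chain carbon bound to a double-bonded chain carbon.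

Among the measured compounds shown here, the only measured step is a step that the two limits leave unreadable from compound 1 to compound 2. It concerns the same aromatic ring that compound 3 exchanges, but it gives no size to carry over. The expectation therefore rests on weak ground: compound 3 is expected to stay close to the limits of its two relatives, and a limit is as likely as a number. If a number is reported, a modest move towards less compound needed in this assay is expected.

The expected step is an at least 1.4-fold lower number from compound 1 to compound 3 (0.16 log units; that floor lies within the scatter). For compound 3 the estimate is 500 umol/kg, with an expected range from 200 umol/kg to 900 umol/kg.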

Compound 3, dose for half-maximal effect: 639 umol/kg
Compound 3: middle estimate off by 1.3-fold (0.11 log units), on the low side; low and high end bracket the measured number.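

In this assay the exchange to 2-chlorophenyl on a double-bonded chain carbon bound to a double-bonded chain carbon gives the only number among the compounds shown, as compound 3 gives 639 umol/kg. This place on the chain therefore tolerates the loss of 3,4-dimethoxyphenyl with a readable result, which neither earlier compound offered. The step is an at least 1.1-fold lower number from compound 1 to compound 3 (0.05 log units; that floor lies within the scatter), so only a floor can be stated, and that floor does not by itself separate compound 3 from compound 1, whose value is a limit and not a number: the limit of > 723 umol/kg in this assay, at which 1 of the 3 values shown sits.

The steps between limits cannot be read, so the methoxy exchange on the aromatic ring gives no size to set beside this one, and the compounds shown do not separate the effect of adding chlorine from that of removing the two methoxy groups. Also open, on these data alone, is whether unsubstituted phenyl, 4-chlorophenyl or a ring bearing an amine or a carboxylic acid at this place would give a number in this assay, and how far that number would lie from that of compound 3.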